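This account rests on a few compounds, and the source may have more. Where it says the series, first, only, none or still open, it means among the compounds named here.

In a functional assay on A549 cells (Homo sapiens) for antiproliferative activity, read by MTT assay, with a stated time of 72 h (on this read-out higher numbers stand for weaker inhibition and lower numbers for stronger inhibition), compound 3 (`C/C=C/C(=O)Nc1cccc(Oc2nc(Nc3cccc(OC)c3)nc3c2CSCC3)c1`) gives 21100 nM. Compound 2 (`C=CC(=O)Nc1cccc(Oc2nc(Nc3cccc(OC)c3)nc3c2CSCC3)c1`) gives 10100 nM, a clearly lower number, while compound 1 (`CC/C=C/C(=O)Nc1cccc(Oc2nc(Nc3ccn(C)n3)nc3c2CSCC3)c1`) gives 36800 nM, within the scatter of compound 3. Compound 4 (`CC/C=C/C(=O)Nc1cccc(Oc2nc(Nc3cccc(OC)c3)nc3c2CSCC3)c1`) differs from compound 3 by methyl in place of hydrogen on a saturated chain carbon bound to a double-bonded chain carbon, turning prop-1-en-1-yl into but-1-en-1-yl. Among the measured compounds shown here, the one measured step that bears on this change is modest: a 2.1-fold higher number from compound 2 to compound 3 (0.32 log units; beyond the scatter). A further small rise in the number is therefore expected in this assay, probably staying within the scatter. The estimated step is a 1.2-fold higher number from compound 3 to compound 4 (0.09 log units; within the scatter). For compound 4 the expected value is 26000 nM, with an estimated range of 12000 nM to 55000 nM.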

Compound 4, half-maximal inhibitory concentration: 17200 nM
Estimate against measurement, compound 4: 1.5-fold (0.18 log units) above; measured number inside the range.
By their numbers in this assay, from the lowest: compounds 2, 4, 3 and 1 (each within the scatter of the next, the first and the last beyond it).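

In this assay, the added methyl that turns prop-1-en-1-yl into but-1-en-1-yl gives a 1.2-fold lower number from compound 3 to compound 4 (0.09 log units; within the scatter), so the rise seen on leaving vinyl does not continue, and but-1-en-1-yl set against vinyl itself gives a 1.7-fold higher number from compound 2 to compound 4 (0.23 log units; within the scatter). With (but-1-en-1-yl)carbonyl held fixed, 3-methoxyphenyl in place of 1-methyl-1H-pyrazol-3-yl on a nitrogen on an aromatic ring gives a 2.1-fold lower number from compound 1 to compound 4 (0.33 log units; beyond the scatter). Nothing measured here accounts for these steps. As far as these compounds go, it remains open how a longer chain than but-1-en-1-yl, or an amine at the end of that chain, would read in this assay.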